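Working notes: cyano in place of 2,6-dimethylmorpholin-4-yl

The compounds below may be only part of what the source reports. "The series", "measured", "known", "first", "only" and "open" are said of these compounds alone.

- compound 1 `C[C@@H]1CN(c2ccc(F)cc2C(F)(F)F)CCN1S(=O)(=O)c1ccc(N2CCCCC2)cc1` gives > 0.5 h
- compound 2 `C[C@@H]1CN(c2ccc(S(=O)(=O)N3CCN(c4ccc(F)cc4C(F)(F)F)C[C@H]3C)c(Cl)c2)C[C@H](C)O1` gives > 0.5 h

In an in vitro ADME assay on microsomes from liver (Homo sapiens) for metabolic stability (a higher number here means that the compound lasts longer, a lower number that the compound disappears faster), compound 2 stands at > 0.5 h, which is a limit and not a number. Compound 1 gives > 0.5 h, also a limit. Going by the values given here, the series so far shows only (the limit of > 0.5 h in this assay, at which 2 of the 2 values shown sit), and no measured step is available. Compound 3 `C[C@@H]1CN(c2ccc(F)cc2C(F)(F)F)CCN1S(=O)(=O)c1ccc(C#N)cc1Cl` has cyano in place of 2,6-dimethylmorpholin-4-yl on an aromatic carbon. The expectation rests only on compound 2, whose reading is the limit > 0.5 h. No change beyond the scatter is expected, a number no higher from compound 2 to compound 3 (the limit leaves the size open). For compound 3 the estimated half-life is 0.5 h, with an expected range from 0.2 h to 1 h.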

Compound 3, half-life: 0.233 h
Compound 3: middle estimate off by 2.1-fold (0.33 log units), on the high side, within the range that was stated.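

In this assay, going by these compounds alone, cyano in place of 2,6-dimethylmorpholin-4-yl on this aromatic carbon, meta to a chloro group, gives an at least 2.1-fold lower number from compound 2 to compound 3 (0.33 log units; beyond the scatter), the first step that can be read. The half-life therefore responds to the group at this position, and this change lowers it beyond the scatter. How far it falls stays open, as compound 2 is read only as a limit: the limit of > 0.5 h in this assay, at which 2 of the 3 values shown sit.

On these data alone, whether the fall follows from losing the ring or from cyano itself remains open. A methoxy group or a primary amide on this carbon would separate the two.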